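Thromboxane synthase series: dioxane acids, variation at the acetal carbon

The source may hold more compounds than are shown below. What is called first, only, known or untested is meant among the compounds shown, and "the series" means these compounds.

Measured so far in an assay for inhibition of Thromboxane-A synthase (Homo sapiens), using microsomes; a higher number here means a weaker inhibitor, a lower number a stronger inhibitor:
- compound 1, `O=C(O)CC/C=C\CC1COC(c2ccc(Cl)cc2Cl)OC1c1cccnc1`: 42 nM
- compound 2, `CC(C)(C)c1ccc(OC(C)(C)C2OCC(C/C=C\CCC(=O)O)C(c3cccnc3)O2)cc1`: 280 nM
- compound 3, `COc1ccc(SC(C)(C)C2OCC(C/C=C\CCC(=O)O)C(c3cccnc3)O2)c([N+](=O)[O-])c1`: 40 nM

Compound 2 carries the highest number of the three in this assay. Compound 1 and compound 3, each built on the same core as compound 2 but with a different group on the acetal carbon, both sit well below it; the gaps from compound 2 to compound 1 and to compound 3 lie beyond the scatter, while the two low values are within the scatter of each other, so neither of those can be called the stronger one.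

Compound 4, `CC(C)(Cc1ccc(F)cc1C#N)C1OCC(C/C=C\CCC(=O)O)C(c2cccnc2)O1`, has not yet been run in this assay. Going by the values given here, its only change from compound 2 is a group of 10 heavy atoms (8 carbon, 1 nitrogen, 1 fluorine; one six-membered aromatic ring of carbon only) in place of a group of 11 heavy atoms (10 carbon, 1 oxygen; one six-membered aromatic ring of carbon only), on a saturated chain carbon bound to two saturated chain carbons and a saturated ring carbon. The 4-(tert-butyl)phenoxy group, the largest substituent in the set, is thus replaced by a group of almost the same size that lacks the oxygen at the point of attachment.

Among the compounds with values here, with no directly comparable pair measured, the direction can only be read from the spread of the three values: the two alternatives to the 4-(tert-butyl)phenoxy group both give lower numbers, so a move downward from compound 2 is expected, of moderate size and possibly beyond the scatter. The expected step of a 2.3-fold lower number from compound 2 to compound 4 (0.37 log units; beyond the scatter) reflects this. Compound 4 is expected to give about 120 nM in this assay, within a range from 40 nM to 400 nM.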

Compound 4, half-maximal inhibitory concentration: < 10 nM
Compound 4 ended at the assay's limit; the forecaster's own chance of this, stated with the estimate: 5%; middle value at least 12-fold (1.07 log units) away from the limit.
By their numbers in this assay, from the lowest: compounds 3 and 1 (each within the scatter of the next); then compound 2. At a limit, below all of these: compound 4.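

The reading for compound 4 in this assay is a limit of the assay and not a number: the limit of < 10 nM in this assay, at which 1 of the 4 values shown sits. At the saturated chain carbon bound to two saturated chain carbons and a saturated ring carbon, replacing the 4-(tert-butyl)phenoxy group with a group of almost the same heavy-atom count, carrying a nitrile and a fluorine on its aromatic ring and no oxygen at the point of attachment, gives an at least 28-fold lower number from compound 2 to compound 4 (1.44 log units; beyond the scatter), so heavy-atom count alone does not set the number at this position. The earlier compounds shown here, with compound 3 at 40 nM and compound 2 at 280 nM, showed only a spread among different groups and no single change at this carbon with a step of this size.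

On these data alone, how far under the limit compound 4 lies remains open, and so does the true size of the step. Also open, as far as these compounds go, is which part of the entering group carries the step: the nitrile, the fluorine or the missing oxygen, which a plain benzyl group or a benzyl group with only a nitrile or only a fluorine at this carbon would begin to separate.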